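Swapping a nitro for a fluorine on the hydrazone arm

The source may hold more compounds than are shown below. What is called first, only, known or untested is meant among the compounds shown, and "the series" means these compounds.

Of the compounds shown here, three sharing one core have been tested in a functional assay on MCF7 cells (Homo sapiens) for inhibition, read by MTT assay, with a stated time of 48 h; on this read-out lower numbers stand for stronger inhibition and higher numbers for weaker inhibition. Compound 1 `Clc1ccc(CSc2nnc(-c3ccncc3)n2-c2ccccc2)cc1` gives 13300 nM in this assay. Compound 2 `Fc1cccc(F)c1CSc1nnc(-c2ccncc2)n1-c1ccccc1` reaches only the limit of this assay, > 50000 nM, so no number is known for it. Compound 3 `O=C(CSc1nnc(-c2ccncc2)n1-c1ccccc1)N/N=C/c1ccc([N+](=O)[O-])cc1` gives 15300 nM in this assay, a value that differs from that of compound 1 only within the scatter. Among the measured compounds shown here, the one measured step, an at least 3.7-fold higher number from compound 1 to compound 2 (0.57 log units; beyond the scatter), shows that changing the aryl group on the chain carbon bound to sulfur can push a compound out to the limit, as noted at the limit of > 50000 nM in this assay, at which 1 of the 3 values shown sits.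

Compound 4 `O=C(CSc1nnc(-c2ccncc2)n1-c1ccccc1)N/N=C/c1cccc(F)c1` differs from compound 3 by 3-fluorophenyl in place of 4-nitrophenyl on a carbon with a double bond to nitrogen. For the measured compounds named here, no measured step touches this position, and the single step from compound 1 to compound 2 involves a different part of the molecule, so it gives only a loose guide. Given the weak values throughout, compound 4 is expected to stay in a similar range, with the step of a 1.3-fold higher number from compound 3 to compound 4 (0.12 log units; within the scatter) estimated as small. Compound 4 is therefore estimated at 20000 nM, between 8000 nM and 50000 nM.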

Compound 4, half-maximal inhibitory concentration: > 50000 nM
Compound 4 gave a limit, no number (the forecaster's own chance of this, stated with the estimate: 25%); middle value at least 2.5-fold (0.39 log units) away from the limit.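

On the arm held by the carbon with a double bond to nitrogen, the aryl group clearly matters: in this assay, putting 3-fluorophenyl in place of 4-nitrophenyl brings an at least 3.2-fold higher number from compound 3 to compound 4 (0.51 log units; beyond the scatter). As far as these compounds go, for compound 4, the value > 50000 nM is a limit of the assay and not a number, so the true size of this step remains unknown. Earlier, only the change from compound 1 to compound 2 had reached this limit, and a change in a second place on the shared core now does the same: the limit of > 50000 nM in this assay, at which 2 of the 4 values shown sit.

The step changes both the group on the ring and where it stands, and the compounds shown do not separate the two. From the compounds shown here alone, how 4-fluorophenyl, 3-nitrophenyl or a phenyl ring carrying an amine would behave on this carbon stays open.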